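From cyanomethyl to oxan-4-yl on an amine nitrogen

A few compounds are considered here, and "the series" means these few. Any claim that something is new, unique, unknown or untested is made for them only; others in the source may bear on it.

Of the compounds shown here, three sharing one core have been measured in an in vitro ADME assay on microsomes from liver (Homo sapiens) for pharmacokinetics, read by LC-MS, with a stated time of 10 min, tested at 1 uM; a higher number here means faster removal of the compound, a lower number slower removal. There, compound 1 `CN1C[C@H](C(=O)Nc2ccc(C(F)(F)F)cc2)[C@@H](c2ccc(/C=C/C(=O)Nc3ccccc3N)cc2)C1` gives 6 mL/min/kg, compound 2 `Cc1cc(NC(=O)[C@H]2CN(C)C[C@@H]2c2ccc(/C=C/C(=O)Nc3ccccc3N)cc2)ccc1F` gives 15 mL/min/kg and compound 3 `N#CCN1C[C@H](C(=O)Nc2ccc(Cl)cc2)[C@@H](c2ccc(/C=C/C(=O)Nc3ccccc3N)cc2)C1` gives 17 mL/min/kg. Compound 3 thus lies within the scatter of compound 2, while its number stands clearly above that of compound 1.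

The next structure, compound 4 `Nc1ccccc1NC(=O)/C=C/c1ccc([C@H]2CN(C3CCOCC3)C[C@@H]2C(=O)Nc2ccc(Cl)cc2)cc1`, keeps the core of compound 3 and changes one group: oxan-4-yl in place of cyanomethyl on an amine nitrogen in a ring.

Among the compounds with values here, only one measured step offers any guide, and it is an indirect one. This is a 2.5-fold higher number from compound 1 to compound 2 (0.40 log units; beyond the scatter), a modest change that lies beyond the scatter but was made on an amide-type nitrogen, not on the amine nitrogen. Compound 2 and compound 3 differ in more than one place, so their values isolate no single group. Within the data shown here, no measured step therefore shows what a change at the amine nitrogen does in this assay, and no shift beyond the scatter is expected in either direction. The estimated change is a 1.1-fold higher number from compound 3 to compound 4 (0.05 log units; within the scatter). Compound 4 is expected to give 19 mL/min/kg, with an estimated range from 8 mL/min/kg to 42 mL/min/kg.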

Compound 4, clearance: 12 mL/min/kg
Compound 4: middle estimate off by 1.6-fold (0.20 log units), on the high side; measured number inside the range.
By their numbers in this assay, from the lowest: compounds 1, 4, 2 and 3 (each within the scatter of the next, the first and the last beyond it).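

The amine nitrogen in the ring now has its first step that changes one place only: in this assay, oxan-4-yl in place of cyanomethyl gives a 1.4-fold lower number from compound 3 to compound 4 (0.15 log units; within the scatter), which lies within the scatter. With the (4-chlorophenyl)carbamoyl group held constant, this assay therefore does not separate an open group of 3 heavy atoms with a triple bond from a six-membered non-aromatic ring group of 6 heavy atoms, although the two share the same printed count of hydrogen-bond acceptors and have no net charge. No measurement shown here offers an explanation for this result.

Within the data shown here, this single step covers only two groups at the amine nitrogen and only one amide partner, so it remains open whether the same holds with the 4-(trifluoromethyl)phenyl or 4-fluoro-3-methylphenyl groups on the amide-type nitrogen, and the methyl group of compound 1 and compound 2 cannot be set against either group here. Also open, going by these compounds, is whether another group on this nitrogen, such as an acetyl group, a chain ending in a carboxylic acid or a longer alkyl chain, would move the number beyond the scatter.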